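The source may hold more compounds than are shown below. What is called first, only, known or untested is meant among the compounds shown, and "the series" means these compounds.

Measured so far:
compound 1 `COC(=O)N[C@H](C(=O)N1CCC[C@H]1C(=O)Nc1ccc([C@H]2CC[C@H](c3ccc(NC(=O)[C@@H]4CCCN4C(=O)[C@@H](NC(=O)OC)C(C)C)cc3)N2c2ccc(C(F)(F)F)cc2)cc1)C(C)C`, in an ADME assay on the whole organism for pharmacokinetics, with Rattus norvegicus as the target, at a dose of 3 mg/kg by the intravenous route; on this read-out lower numbers stand for slow clearance and higher numbers for fast clearance: 4.83 mL/min/kg
compound 2 `COC(=O)N[C@H](C(=O)N1CCC[C@H]1C(=O)Nc1ccc([C@@H]2CC[C@@H](c3ccc(NC(=O)[C@@H]4CCCN4C(=O)[C@@H](NC(=O)OC)[C@H]4CCOC4)cc3)N2c2ccc(F)cc2)cc1)[C@H]1CCOC1`, in this assay: 31.7 mL/min/kg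

Compound 1 has the lowest of the two numbers; compound 2 sits higher, and that gap lies beyond the scatter. Compound 3 `COC(=O)N[C@H](C(=O)N1CCC[C@H]1C(=O)Nc1ccc([C@@H]2CC[C@@H](c3ccc(NC(=O)[C@@H]4CCCN4C(=O)[C@@H](NC(=O)OC)C(C)C)cc3)N2c2ccc(C(F)(F)F)cc2)cc1)C(C)C` differs from compound 1 only in configuration: the two compounds have the same atoms and bonds and differ only in configuration as drawn: 2 of 6 stereo elements differ; a stereocentre at a saturated ring carbon is drawn R in compound 1 and S in compound 3; a stereocentre at a saturated ring carbon is drawn R in compound 1 and S in compound 3. For the measured compounds named here, no pair of measured compounds shows a step of this kind, so the size of the change is open. A small rise in this assay is expected for compound 3, with the step from compound 1 read as a 1.7-fold higher number from compound 1 to compound 3 (0.22 log units; within the scatter). Compound 3 is therefore estimated at 8 mL/min/kg, in a range from 3 mL/min/kg to 20 mL/min/kg.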

Compound 3, clearance: 20 mL/min/kg
The estimate for compound 3 lay 2.5-fold (0.40 log units) below the measured number; low and high end bracket the measured number.
By their numbers in this assay, from the lowest: compound 1; then compounds 3 and 2 (each within the scatter of the next).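

Inverting the two saturated ring carbons while keeping all atoms and bonds gives a 4.1-fold higher number from compound 1 to compound 3 (0.62 log units; beyond the scatter) in this assay. For the compounds shown here, the earlier compounds offered no step between compounds differing in one place, so this is the first sign that configuration at these carbons matters for clearance. The step can be assigned to configuration alone, because nothing else separates the pair: the fact that compounds 1 and 3 differ only in the configuration as drawn

Which of the two stereocentres carries the step remains open. Also open, as far as these compounds go, is whether the same inversion gives a step of similar size when an amine or a carboxylic acid replaces the trifluoromethyl group.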